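This account rests on a few compounds, and the source may have more. Where it says the series, first, only, none or still open, it means among the compounds named here.

Compound 3 `CC(C)(C)c1cc(C(=O)Nc2ccncc2)n(Cc2ccccc2)n1` was measured in a physicochemical assay for lipophilicity, read by HPLC, at pH 3.0 (a higher number here means a more lipophilic compound, a lower number a more polar compound), where compound 3 gives 2.6. Two other compounds give points of comparison: compound 2 `NCc1csc(NC(=O)c2cc3ccccc3n2Cc2ccccc2)n1`, which in this assay gives 2.4, and compound 1 `NCc1csc(NC(=O)c2ccn[nH]2)n1`, which gives 0. The numbers of compound 3 and compound 2 lie within the scatter of each other, while compound 1 lies far below both.

Compound 4 `CC(C)(C)c1cc(C(=O)Nc2nc(CO)cs2)n(Cc2ccccc2)n1` has not yet been measured in this assay. It differs from compound 3 in one place: 4-(hydroxymethyl)-1,3-thiazol-2-yl in place of pyridin-4-yl on an amide-type nitrogen. Among the measured compounds shown here, no measured pair shows this exact change, so its effect is unknown. The step from compound 3 to compound 4 is expected to be small, a number 0.20 log units higher from compound 3 to compound 4 (within the scatter), possibly not beyond the scatter. Compound 4 is therefore estimated at 2.8, with a likely range from 2.2 to 3.4.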

Compound 4, distribution coefficient: 3.5
Compound 4: the middle estimate sits 0.70 log units below what was measured; the measured number lies above the stated range.
By their numbers in this assay, from the lowest: compound 1; then compounds 2 and 3 (each within the scatter of the next); then compound 4.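

In this assay compound 4 shows that the group on this amide-type nitrogen can shift the reading: replacing pyridin-4-yl with 4-(hydroxymethyl)-1,3-thiazol-2-yl gives a number 0.90 log units higher from compound 3 to compound 4 (beyond the scatter) for this change. The entering group brings a hydrogen-bond donor that pyridin-4-yl lacks, yet the number still rises. Nothing available accounts for this step.

The compounds shown do not separate the share of the 1,3-thiazol-2-yl ring from that of the hydroxymethyl group. Going by these compounds, it also remains open how a carboxylic acid or a methoxy group in place of the hydroxyl would read in this assay on this ring.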